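The source may hold more compounds than are shown below. What is called first, only, known or untested is meant among the compounds shown, and "the series" means these compounds.

Compound 1 `O=S(=O)(Nc1ccc2oc(-c3ccccc3)nc2c1)c1cccc(F)c1`: 68000 nM
Compound 2 `O=S(=O)(Nc1ccc2oc(-c3ccccc3)nc2c1)c1ccccc1Cl`: 73000 nM
Compound 3 `O=S(=O)(Nc1ccc2oc(-c3ccccc3)nc2c1)c1cccc(O)c1`: > 100000 nM, a limit of the assay

These results come from an ADME assay on HEK293 cells (Homo sapiens) for cytotoxicity, read by resazurin assay, with a stated time of 48 h; on this read-out lower numbers stand for higher toxicity in this test and higher numbers for lower toxicity in this test. Among the measured compounds shown here, compound 2, at 73000 nM, cannot be told apart from the only other compound with a true number, as the step shows: a 1.1-fold higher number from compound 1 to compound 2 (0.03 log units; within the scatter). Compound 4 `O=S(=O)(Nc1ccc2oc(-c3ccccc3)nc2c1)c1ccccc1C(F)(F)F` carries trifluoromethyl in place of chloro on an aromatic carbon, ortho to a large group (trifluoromethyl in place of chloro on an aromatic carbon). The nearest guide is the swap of the group on the sulfonyl sulfur, which stayed small: a 1.1-fold higher number from compound 1 to compound 2 (0.03 log units; within the scatter). The swap to compound 3 shows only a floor within the scatter: an at least 1.3-fold higher number from compound 2 to compound 3 (0.13 log units; that floor lies within the scatter). No step beyond the scatter is therefore expected in this assay. The expected change is a 1.1-fold lower number from compound 2 to compound 4 (0.05 log units; within the scatter). For compound 4 the estimated value is 65000 nM, with an expected range from 32000 nM to 100000 nM.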

Compound 4, half-maximal cytotoxic concentration: 80000 nM
Compound 4: the middle estimate sits 1.2-fold (0.09 log units) below what was measured; low and high end bracket the measured number.
By their numbers in this assay, from the lowest: compounds 1, 2 and 4 (each within the scatter of the next). At a limit, above all of these: compound 3.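

Trifluoromethyl in place of chloro, on an aromatic carbon ortho to a large group, gives a 1.1-fold higher number from compound 2 to compound 4 (0.04 log units; within the scatter) in this assay. The earlier steps shown here exchanged the whole group on the sulfonyl sulfur, whereas this one alters a single place on that ring, and the cytotoxicity read-out again does not separate the pair. Compound 3 alone stands at a limit of the assay: the limit of > 100000 nM in this assay, at which 1 of the 4 values shown sits.

As far as these compounds go, whether an amine or a carboxylic acid at this same position would shift the number remains open. So does the effect of any such group on the shared core.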